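Pyridyl position and liver S9 stability across two cores

The source may report more compounds than this note shows. Statements on the series, on what has been measured and on what is new or still open speak of the compounds shown alone.

The series pairs an octyl-phenyl ether ketone chain with a five-membered aromatic ring with 4 nitrogen that carries a pyridyl group, and is read in an ADME assay on S9 fraction from liver (Rattus norvegicus) for metabolic stability, read by LC-MS, using NADPH, with a stated time of 30 min; a higher number here means that more of the compound is left, a lower number that less of the compound is left. Compound 1 `CCCCCCCCc1ccc(OCC(=O)Cn2nnc(-c3ccncc3)n2)cc1` sits at a limit of the assay, < 5%, which is a limit and not a number; this is the limit described by the limit of < 5% in this assay, at which 1 of the 3 values shown sits. Compound 2 `CCCCCCCCc1ccc(OCC(=O)Cn2nnc(-c3cccnc3)n2)cc1` gives 12%. The change between them is pyridin-3-yl in place of pyridin-4-yl on an aromatic carbon and the step is a number at least 7 percentage points higher from compound 1 to compound 2 (that floor lies within the scatter); its floor lies within the scatter, so the size of the gain is uncertain.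

Compound 3 `CCCCCCCCc1ccc(OCC(=O)Cn2nnnc2-c2ccncc2)cc1` has a different core; how the cores of compound 1 and compound 3 differ is not broken down here. In this assay compound 3 gives 24%, the highest of the two numbers shown and beyond the scatter from compound 2.

Compound 4 `CCCCCCCCc1ccc(OCC(=O)Cn2nnnc2-c2cccnc2)cc1` has not yet been measured. It differs from compound 3 by pyridin-3-yl in place of pyridin-4-yl on an aromatic carbon. This is the same kind of change as that from compound 1 to compound 2, but not the same: here the carbon is next to the ring atom that bears a large group, whereas in the first pair it was two ring bonds from that atom. The step is expected to be a number 6 percentage points higher from compound 3 to compound 4 (within the scatter), small and within the scatter, resting on the step from compound 1 to compound 2 being at least a number at least 7 percentage points higher from compound 1 to compound 2 (that floor lies within the scatter). Compound 4 is therefore estimated at 30%, ranging from 15% to 50%.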

Compound 4, percent of the compound remaining: 20%
Beside the measured number, compound 4's estimate is 10 percentage points above it; low and high end bracket the measured number.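

In this assay the replacement of pyridin-4-yl by pyridin-3-yl on the core of compound 3 reads as a number 4 percentage points lower from compound 3 to compound 4 (within the scatter), so on this core the change does not separate the two compounds. Set beside the same change on the core of compound 1, this result neither shows that the change carries over from one core to the other nor shows that it fails to carry over: the same change on two cores in this assay, a number at least 7 percentage points higher (that floor lies within the scatter) from compound 1 to compound 2 and a number 4 percentage points lower (within the scatter) from compound 3 to compound 4; the limit leaves it open whether they differ. Among the compounds shown here, the comparison also rests on only two pairs, and one end of it is compound 1, whose entry is a limit of the assay and not a number: the limit of < 5% in this assay, at which 1 of the 4 values shown sits.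

The compounds shown leave open how the same change would read with pyridin-2-yl or a plain phenyl ring in place of either pyridyl group on the two cores, which would test whether the pyridyl nitrogen matters at all in this read-out. They also leave open whether any difference between the cores would persist with a shorter chain in place of octyl, or with an alcohol in place of the ketone carbonyl.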